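Metabolic stability of side-chain heterocycle variants

A few compounds are considered here, and "the series" means these few. Any claim that something is new, unique, unknown or untested is made for them only; others in the source may bear on it.

Values in an ADME assay on microsomes from liver (Mus musculus) for metabolic stability (a lower number here means that the compound disappears faster, a higher number that the compound lasts longer), so far:
compound 1 `CC(C)C(CC(N)=O)c1ccc(-c2ccc3cccc(F)c3c2)[nH]c1=O`: < 0.0667 h
compound 2 `Cc1nc(C(c2ccc(-c3ccc4cccc(F)c4c3)[nH]c2=O)C(C)C)[nH]c1C`: 0.0817 h
compound 3 `CC(C)C(Cc1noc(=O)[nH]1)c1ccc(-c2ccc3cccc(F)c3c2)[nH]c1=O`: 2.78 h

Among these entries, compound 1 gives < 0.0667 h, which is a limit of the assay, not a number (the limit of < 0.0667 h in this assay, at which 1 of the 3 values shown sits).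

Compound 3 stands highest of the two numbers shown, and the gap to its nearest neighbour is large: a 34-fold higher number from compound 2 to compound 3 (1.53 log units; beyond the scatter). Compound 4 `CC(C)C(Cc1nnc[nH]1)c1ccc(-c2ccc3cccc(F)c3c2)[nH]c1=O` differs from compound 3 by a group of 5 heavy atoms (2 carbon, 3 nitrogen; one five-membered aromatic ring with 3 hetero atoms) in place of a group of 6 heavy atoms (2 carbon, 2 nitrogen, 2 oxygen; one five-membered aromatic ring with 3 hetero atoms), on a saturated chain carbon, two bonds along the chain from an aromatic carbon. Among the compounds with values here, no measured step isolates this change. Both large steps, an at least 41-fold higher number from compound 1 to compound 3 (1.61 log units; beyond the scatter) and a 34-fold higher number from compound 2 to compound 3 (1.53 log units; beyond the scatter), end at compound 3, while an at least 1.2-fold higher number from compound 1 to compound 2 (0.08 log units; that floor lies within the scatter) shows that a five-membered aromatic ring with 2 hetero atoms alone brought no gain beyond the scatter. Part of the gain is therefore expected to be given up, with the estimated step of a 4.0-fold lower number from compound 3 to compound 4 (0.60 log units; beyond the scatter), a decrease beyond the scatter. Compound 4 is expected at 0.7 h, within 0.2 h to 2.5 h.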

Compound 4, half-life in the Mus musculus assay: < 0.0667 h
Compound 4: only a limit was reported; the forecaster's own chance of this, stated with the estimate: 10%; at least 10-fold (1.02 log units) between middle value and limit.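

Having a five-membered aromatic ring with 3 hetero atoms at this position is not enough in the Mus musculus assay: the change to 4H-1,2,4-triazol-3-yl gives an at least 41-fold lower number from compound 3 to compound 4 (1.61 log units; beyond the scatter), and an at least 1.2-fold lower number from compound 2 to compound 4 (0.08 log units; that floor lies within the scatter) does not set compound 4 clearly apart from compound 2. The step between compound 1 and compound 4 cannot be read, since both sit at a limit: the limit of < 0.0667 h in the Mus musculus assay, at which 2 of the 4 values shown sit. In a physicochemical assay for solubility, in phosphate buffer, measured as kinetic solubility (on this read-out lower numbers stand for lower solubility and higher numbers for higher solubility), compound 3 gives 30400 nM and compound 4 gives 24200 nM, and a 1.3-fold lower number from compound 3 to compound 4 (0.10 log units; within the scatter) means this read-out does not separate the two.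

Which part of the ring in compound 3 carries its stability stays open. So does how a carboxylic acid or a tetrazole at this position would fare in the Mus musculus assay.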